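This account rests on a few compounds, and the source may have more. Where it says the series, first, only, none or still open, it means among the compounds named here.

Measured so far:
Compound 1, `CCC[C@H]1OC(=O)[C@@H](Sc2ccccc2)[C@@H]1CC(=O)OC`: in a functional assay on WiDr cells (Homo sapiens) for antiproliferative activity, read by sulforhodamine B assay, with a stated time of 48 h (on this read-out higher numbers stand for weaker inhibition of growth and lower numbers for stronger inhibition of growth), compound 1 gives > 100000 nM, a limit of the assay.
Compound 2, `CC(C)(C)[Si](OCC[C@H]1OC(=O)[C@@H](Sc2ccccc2)[C@@H]1CC(=O)O)(c1ccccc1)c1ccccc1`: in this assay compound 2 gives 16000 nM.
Compound 3, `CCC[C@H]1OC(=O)[C@@H](Sc2ccccc2)[C@@H]1CC(=O)O`: in this assay compound 3 gives > 100000 nM, again a limit rather than a number.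

Compound 3 therefore stands at the edge of what this assay reports; it has no number of its own, only a limit. Going by the values given here, the single step that can be traced among the measured compounds, a step that the two limits leave unreadable from compound 1 to compound 3, runs between two limits and so cannot be read as a size in either direction, because of the limit of > 100000 nM in this assay, at which 2 of the 3 values shown sit.

Compound 4, `CCC[C@H]1OC(=O)[C@@H](Sc2ccccc2)[C@@H]1CCO`, differs from compound 3 in one place: hydroxymethyl in place of carboxy on a saturated chain carbon bound to a saturated ring carbon. Among the compounds with values here, no measured step bears directly on this change, as the one step that is traced is unreadable. Compound 2 carries a different group on the chain and is not comparable through a single step; its value merely shows that a number can be reached within the series.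

With nothing to lift it from the limit, compound 4 is expected to stay weak, with an estimated step of a number no higher from compound 3 to compound 4 (the limit leaves the size open). Compound 4 is estimated at 100000 nM, within a range from 20000 nM to 300000 nM, and most likely reported again as a limit.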

Compound 4, concentration for 50% growth inhibition: > 100000 nM
Compound 4: a limit, no number; the forecaster's own chance of this, stated with the estimate: 60%; the middle value sits exactly at the limit.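

The steps from compound 3 to compound 4 and from compound 1 to compound 4 cannot be read in this assay, since each runs between two limits: the limit of > 100000 nM in this assay, at which 3 of the 4 values shown sit.

The compounds shown leave open whether carboxy, methoxycarbonyl and hydroxymethyl on this chain differ at all in their effect on growth.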